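The source may hold more compounds than are shown below. What is called first, only, known or untested is meant among the compounds shown, and "the series" means these compounds.

Measured values in this series:

compound 1 `CCOC(=O)c1cnc(N2CCN(Cc3ccc(C(F)(F)F)cc3)CC2)nc1Oc1c(C)cc(-c2ccc(C#N)cc2)cc1C` — in an ADME assay on MT4 cells (Homo sapiens) for cytotoxicity, read by MTT assay, with a stated time of 4 days (a lower number here means that less compound is tolerated, a higher number that more compound is tolerated), compound 1 gives > 125000 nM, a limit of the assay.
compound 2 `CCOC(=O)c1cnc(N2CCN(Cc3cccc(C(F)(F)F)c3)CC2)nc1Oc1c(C)cc(-c2ccc(C#N)cc2)cc1C` — in this assay compound 2 gives > 125000 nM, a limit of the assay.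
compound 3 `CCOC(=O)c1cnc(N2CCN(Cc3ccccc3[N+](=O)[O-])CC2)nc1Oc1c(C)cc(-c2ccc(C#N)cc2)cc1C` — in this assay compound 3 gives >= 78700 nM, a limit of the assay.

Compound 3 stands only at a limit, as the limit of >= 78700 nM in this assay, at which 1 of the 3 values shown sits, records; the other two sit at the limit of > 125000 nM in this assay, at which 2 of the 3 values shown sit. All three measured steps are unreadable: a step that the two limits leave unreadable from compound 1 to compound 2, a step that the two limits leave unreadable from compound 1 to compound 3, a step that the two limits leave unreadable from compound 2 to compound 3. None of them separates the benzyl variants.

Compound 4 `CCOC(=O)c1cnc(N2CCN(Cc3cccc(OC)c3)CC2)nc1Oc1c(C)cc(-c2ccc(C#N)cc2)cc1C` carries 3-methoxyphenyl in place of 2-nitrophenyl on a saturated chain carbon bound to an amine nitrogen in a ring. Going by the values given here, no measured step reads a size for any change at this position, so no step beyond the scatter is expected in this assay; the expected step is a step that the limit leaves unreadable from compound 3 to compound 4. Compound 4 is therefore estimated at 125000 nM, in the range 60000 nM to 250000 nM, most likely reported as a limit.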

Compound 4, half-maximal cytotoxic concentration: > 125000 nM
Compound 4 gave a limit, no number; the forecaster's own chance of this, stated with the estimate: 85%; the middle value lies on the limit itself.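

In this assay compound 4 gives > 125000 nM, a limit of the assay; its steps from compound 1, compound 2 and compound 3 cannot be read. On these data alone, whether these four benzyl variants differ at all in this assay remains open.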